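This account rests on a few compounds, and the source may have more. Where it says the series, first, only, none or still open, it means among the compounds named here.

Measured so far in a functional assay on Caco-2 cells (Homo sapiens) for inhibition, read by MTT assay, with a stated time of 48 h, tested at 10 uM (a lower number here means less inhibition of growth, a higher number more inhibition of growth at the concentration tested), for the series:
compound 1 `Cc1oc2c([C@H]3CCN(C)C[C@H]3O)c(O)cc(O)c2c(=O)c1C(O)c1c(F)cccc1Cl` gives 18%
compound 2 `CCCCCCCCCC/C=C/c1c(C)oc2c([C@H]3CCN(C)C[C@H]3O)c(O)cc(O)c2c1=O` gives 10%

Compound 1 stands level with compound 2 within the usual scatter, and these two values do not separate. The next compound to be read is compound 3 `Cc1oc2c([C@H]3CCN(C)C[C@H]3O)c(O)cc(O)c2c(=O)c1C(O)c1ccc(F)cc1`, where the change from compound 1 is 4-fluorophenyl in place of 2-chloro-6-fluorophenyl on a saturated chain carbon bound to an aromatic carbon and an oxygen on a saturated carbon, with 4-fluorophenyl in place of 2-chloro-6-fluorophenyl on a saturated chain carbon bound to an aromatic carbon and an oxygen on a saturated carbon. Among the compounds with values here, no measured pair differs in one place, so the expectation rests on little. Within the data shown here, with compound 1 at 18% and compound 2 at 10% as the only guides, no step beyond the scatter is expected in this assay. The expected size is a number 3 percentage points lower from compound 1 to compound 3 (within the scatter), within the scatter. For compound 3 the estimated value is 15% (expected range 4% to 29%).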

Compound 3, percent growth inhibition at one concentration: 11%
Beside the measured number, compound 3's estimate is 4 percentage points above it, and the stated range covers the measured number.
By their numbers in this assay, from the lowest: compounds 2, 3 and 1 (each within the scatter of the next).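

In this assay, within the data shown here, 4-fluorophenyl in place of 2-chloro-6-fluorophenyl on a saturated chain carbon bound to an aromatic carbon and an oxygen on a saturated carbon gives the first one-place step: a number 7 percentage points lower from compound 1 to compound 3 (within the scatter). The two aryl groups therefore do not separate in this assay, so this exchange, which also removes the chlorine, gives no measurable handle on growth inhibition at the concentration tested. No supporting measurement bears on this reading or links it to any feature of either group.

On these data alone, it remains open whether any group at this position can move the reading beyond the scatter, for example an unsubstituted phenyl, a primary amine or a carboxylic acid in place of the aryl group. As far as these compounds go, the role of the hydroxyl on the same chain carbon also remains open, as a compound with a ketone carbonyl there would test it.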